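Swapping the halophenyl group on the carbonyl carbon

This account rests on a few compounds, and the source may have more. Where it says the series, first, only, none or still open, it means among the compounds named here.

The two measured compounds share one core and differ only in the group on a carbonyl carbon. Compound 1 `COc1ccc(C(=O)c2cc(C)ccc2OCC(=O)NNC(=O)c2cc3ccccc3oc2=O)cc1` gives 42000 nM in a functional assay on DLA cells (Mus musculus) for cytotoxicity, read by MTT assay, with a stated time of 48 h; a lower number here means a stronger inhibitor, a higher number a weaker inhibitor. Compound 2 `Cc1ccc(OCC(=O)NNC(=O)c2cc3ccccc3oc2=O)c(C(=O)c2cccc(Cl)c2)c1` gives 65500 nM in this assay, the higher of the two numbers; the step of a 1.6-fold higher number from compound 1 to compound 2 (0.19 log units; within the scatter) is the only one recorded and it lies within the scatter. Compound 3 `Cc1ccc(OCC(=O)NNC(=O)c2cc3ccccc3oc2=O)c(C(=O)c2ccccc2Br)c1` is not yet measured; it differs from compound 2 by 2-bromophenyl in place of 3-chlorophenyl on a carbonyl carbon. For the measured compounds named here, no measured step concerns a 2-bromophenyl group, so the only guide is that the one recorded exchange at this carbonyl carbon, from compound 1 to compound 2, moved the number by less than the scatter. On that basis the exchange of 3-chlorophenyl for 2-bromophenyl is expected to bring no step beyond the scatter in this assay, with the direction undetermined, so compound 3 is expected to sit close to compound 2, as the expected step of a 1.1-fold lower number from compound 2 to compound 3 (0.04 log units; within the scatter) states. Compound 3 is therefore estimated at 60000 nM, within a range from 25000 nM to 150000 nM.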

Compound 3, half-maximal inhibitory concentration: 10000 nM
Beside the measured number, compound 3's estimate is 6.0-fold (0.78 log units) above it, and the stated range ends above it.
By their numbers in this assay, from the lowest: compound 3; then compounds 1 and 2 (each within the scatter of the next).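

The result shows that this carbonyl carbon is not indifferent to the aryl group it carries in this assay: the earlier exchange gave only a 1.6-fold higher number from compound 1 to compound 2 (0.19 log units; within the scatter), within the scatter, whereas 2-bromophenyl brings a 6.6-fold lower number from compound 2 to compound 3 (0.82 log units; beyond the scatter) and, against the 4-methoxyphenyl group, a 4.2-fold lower number from compound 1 to compound 3 (0.62 log units; beyond the scatter). Both of these steps lie beyond the scatter and both are modest, so compound 3 holds the lowest number of the three, while compounds 1 and 2 remain within the scatter of each other and take no order between them. No measurement is available that would account for this difference between the groups.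

The exchange from compound 2 to compound 3 alters both the halogen and its place on the phenyl ring, so these compounds cannot tell whether the bromine or its placement carries the step. A 2-chlorophenyl or a 3-bromophenyl group would separate the two, and an unsubstituted phenyl group would show how much any substituent on this ring contributes.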